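Shortening a saturated chain end: expected effect on cytotoxicity

This account rests on a few compounds, and the source may have more. Where it says the series, first, only, none or still open, it means among the compounds named here.

compound 1 `C#C/C=C\CCCCCCCCCCCCCCC/C=C\CCCC/C=C\CCCCC#C[C@@H](O)C#CCCCCCC/C=C/[C@H](O)C#C`: 1.7 ug/mL
compound 2 `C#C/C=C\CCCCCCCCCCCCCC/C=C\CCCC/C=C\CCCCc1cc(=O)cc(CCCCCC/C=C/C(O)C#C)o1`: 7.5 ug/mL

Among the measured compounds shown here, in a functional assay on HCT-15 cells (Homo sapiens) for cytotoxicity (on this read-out lower numbers stand for an effect already at smaller amounts and higher numbers for an effect only at larger amounts of compound), compound 1 gives 1.7 ug/mL, the lower of the two numbers so far. Compound 2 gives 7.5 ug/mL, and this gap lies beyond the scatter. For the measured compounds named here, no measured pair yet differs in one place only, so the data show no step of this kind to draw on.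

The next compound is compound 3 `C#C/C=C\CCCCCCCCCCCCC/C=C\CCCC/C=C\CCCCC#C[C@@H](O)C#CCCCCCC/C=C/[C@H](O)C#C`. Its change from compound 1 is a group of 4 heavy atoms (4 carbon; no ring) in place of a group of 6 heavy atoms (6 carbon; no ring), on a saturated chain carbon, ten or more bonds along the chain from a double-bonded chain carbon. The rest of the structure stays the same. With nothing measured on this kind of change, the expectation rests on compound 1 at 1.7 ug/mL, and no step beyond the scatter is expected in this assay, in either direction. The estimated step of a 1.1-fold higher number from compound 1 to compound 3 (0.02 log units; within the scatter) is expected to stay within the scatter. The estimate for compound 3 is 1.8 ug/mL, with an expected range of 0.8 ug/mL to 4 ug/mL.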

Compound 3, concentration for half-maximal effect: 3.5 ug/mL
Compound 3: middle estimate off by 1.9-fold (0.29 log units), on the low side; the range from low to high includes it.
By their numbers in this assay, from the lowest: compound 1; then compound 3; then compound 2.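

In this assay, a group of 4 heavy atoms (4 carbon; no ring) in place of a group of 6 heavy atoms (6 carbon; no ring), on a saturated chain carbon, ten or more bonds along the chain from a double-bonded chain carbon, gives a 2.1-fold higher number from compound 1 to compound 3 (0.31 log units; beyond the scatter). Among the compounds shown here, this is the first one-place comparison, and it shows that the read-out responds to a change at this position, though only by a modest step. Nothing available explains this step.

From the compounds shown here alone, whether a longer chain at this position would lower the number, or an amine or a carboxylic acid there would raise it, remains open. A single step also leaves open whether the same change would give a similar step on the core of compound 2.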